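Methoxy for Chloro on a Diaryl Thiourea

This account rests on a few compounds, and the source may have more. Where it says the series, first, only, none or still open, it means among the compounds named here.

Among the compounds with values here, compound 1 `CNC(=O)c1ccc(Oc2cccc(NC(=S)Nc3ccc(Cl)cc3)c2)nc1` gives 66500 nM in a functional assay on MDA-MB-231 cells (Homo sapiens) for antiproliferative activity, read by MTT assay (on this read-out higher numbers stand for weaker inhibition and lower numbers for stronger inhibition), the higher of the two numbers recorded; its only neighbour, compound 2 `CNC(=O)c1ccc(Oc2cccc(NC(=S)Nc3ccc(F)cc3)c2)nc1`, gives 21700 nM. Within the data shown here, the single known step, a 3.1-fold lower number from compound 1 to compound 2 (0.49 log units; beyond the scatter), concerns a halogen exchange. Compound 3 `CNC(=O)c1ccc(Oc2cccc(NC(=S)Nc3ccc(OC)cc3)c2)nc1` differs from compound 1 by methoxy in place of chloro on an aromatic carbon. Among the measured compounds shown here, no measured step involves a methoxy group, so the halogen step offers only a loose guide. For compound 3 the expected step is a 1.7-fold lower number from compound 1 to compound 3 (0.22 log units; within the scatter), little beyond the scatter. Compound 3 is therefore estimated at 40000 nM, with a range from 12000 nM to 130000 nM.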

Compound 3, half-maximal inhibitory concentration: 31500 nM
Beside the measured number, compound 3's estimate is 1.3-fold (0.10 log units) above it; the range from low to high includes it.
By their numbers in this assay, from the lowest: compounds 2 and 3 (each within the scatter of the next); then compound 1.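

At this position in this assay, a group other than a halogen also shifts the number: methoxy in place of chloro brings a 2.1-fold lower number from compound 1 to compound 3 (0.32 log units; beyond the scatter). Methoxy in place of fluoro brings only a 1.5-fold higher number from compound 2 to compound 3 (0.16 log units; within the scatter), so among these three groups chloro alone stands apart, while methoxy and fluoro cannot be told apart. Nothing available bears on the reason for these steps. On these data alone, it remains open how an amine, a carboxylic acid or a longer alkoxy chain would behave at this position, and whether chloro would stand apart in the same way elsewhere on the shared core.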